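From hydroxy to methoxy on compound 3

The compounds below may be only part of what the source reports. "The series", "measured", "known", "first", "only" and "open" are said of these compounds alone.

Values in a functional assay on SK-MEL-28 cells (Homo sapiens) for inhibition; on this read-out higher numbers stand for weaker inhibition and lower numbers for stronger inhibition:
compound 1 `COCCOc1cc(/C=C/c2ccc3ccccc3c2)ccc1OC`: 2990 nM
compound 2 `CC(=O)Oc1ccc(/C=C/c2ccc3ccccc3c2)cc1`: > 5000 nM, a limit of the assay and not a number
compound 3 `Oc1ccc(/C=C/c2ccc3ccccc3c2)cc1`: 4060 nM

Compound 3 gives 4060 nM and compound 1 gives 2990 nM, two values within the scatter of each other. Compound 2 is recorded only as a limit, (the limit of > 5000 nM in this assay, at which 1 of the 3 values shown sits).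

Compound 4 `COc1ccc(/C=C/c2ccc3ccccc3c2)cc1` differs from compound 3 in one place: methyl in place of hydrogen on an oxygen on an aromatic ring. This is methyl in place of hydrogen on an oxygen on an aromatic ring, or hydroxy to methoxy.

Within the data shown here, one measured step bears on that oxygen: an at least 1.2-fold lower number from compound 2 to compound 3 (0.09 log units; that floor lies within the scatter). It starts from a limit, so it gives only a floor and not a size, and it concerns acetyl rather than methyl. With no step beyond the scatter at this oxygen, no change beyond the scatter is expected in this assay.

The expected step is a 1.4-fold lower number from compound 3 to compound 4 (0.13 log units; within the scatter). For compound 4 the estimated value is 3000 nM, with an expected range from 1000 nM to 6000 nM.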

Compound 4, half-maximal inhibitory concentration: > 5000 nM
Compound 4 was reported as a limit; the forecaster's own chance of this, stated with the estimate: 25%; middle value at least 1.6-fold (0.22 log units) from the limit.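

Among the groups on this oxygen, only hydrogen, in compound 3, gives a number, while compound 4 with methyl is a limit and not a number in this assay, as is compound 2 with acetyl: the limit of > 5000 nM in this assay, at which 2 of the 4 values shown sit.

Two floors can be read, an at least 1.2-fold higher number from compound 3 to compound 4 (0.09 log units; that floor lies within the scatter) and an at least 1.6-fold higher number from compound 1 to compound 4 (0.22 log units; that floor lies within the scatter); neither gives a size, so a real loss from methyl is neither shown nor excluded, but the small gain expected for this change does not appear. The step between compound 2 and compound 4 cannot be read, since both are limits.

Open, from the compounds shown here alone, is whether methyl and acetyl differ at all on this oxygen, since neither has a number. Also open, going by these compounds, is whether an amine or a carboxylic acid in place of the hydroxy would move the value beyond the scatter of compound 3.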